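The source may report more compounds than this note shows. Statements on the series, on what has been measured and on what is new or still open speak of the compounds shown alone.

Going by the values given here, in a functional assay on MCF7 cells (Homo sapiens) for antiproliferative activity, read by MTT assay, with a stated time of 48 h (on this read-out lower numbers stand for stronger inhibition and higher numbers for weaker inhibition), compound 1 (`CCn1c(C(=O)NCCCN(C)C)ccc1C(CC)(CC)c1ccc(OCCC(O)(CC)CC)c(C)c1`) gives 3350 nM and compound 2 (`CCn1c(C(=O)NCCN)ccc1C(CC)(CC)c1ccc(OCCC(O)(CC)CC)c(C)c1`) gives 670 nM, so compound 2 holds the lower of the two numbers so far. The next compound is compound 3 (`CCn1c(C(=O)N(CCC#N)CCC#N)ccc1C(CC)(CC)c1ccc(OCCC(O)(CC)CC)c(C)c1`), and the change from compound 2 is a group of 9 heavy atoms (6 carbon, 3 nitrogen; no ring) in place of a group of 4 heavy atoms (2 carbon, 2 nitrogen; no ring), on a carbonyl carbon. Among the compounds with values here, only one measured step bears on this change: a 5.0-fold lower number from compound 1 to compound 2 (0.70 log units; beyond the scatter), a modest step beyond the scatter, with amino in place of (dimethylamino)methyl on a saturated chain carbon. There, the compound with the smaller group has the lower number. That single step is a thin guide, since compound 3 replaces the whole group on the carbonyl carbon. A step of similar modest size towards a higher number is nevertheless expected in this assay. The estimate means a 3.0-fold higher number from compound 2 to compound 3 (0.47 log units; beyond the scatter). Compound 3 is expected at 2000 nM, within a range of 600 nM to 7000 nM.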

Compound 3, half-maximal inhibitory concentration: > 50000 nM
Compound 3 gave a limit, no number (the forecaster's own chance of this, stated with the estimate: 5%); middle value at least 25-fold (1.39 log units) away from the limit.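

In this assay, compound 3 gives a limit and not a number: the limit of > 50000 nM in this assay, at which 1 of the 3 values shown sits. On the carbonyl carbon, the group of 9 heavy atoms, with 2 triple bonds and 0 hydrogen-bond donors, gives an at least 74-fold higher number from compound 2 to compound 3 (1.87 log units; beyond the scatter) and an at least 14-fold higher number from compound 1 to compound 3 (1.17 log units; beyond the scatter). The earlier pair showed only a 5.0-fold lower number from compound 1 to compound 2 (0.70 log units; beyond the scatter), so the read-out can move much further with a change at this position than that step indicated.

The heavy-atom count, the triple bonds and the loss of hydrogen-bond donors all change together here, so the compounds shown do not tell which of them matters. A (2-cyanoethyl)amino group, which keeps the amide hydrogen, or a (3-hydroxypropyl)amino group on the same carbonyl carbon would help to separate these changes.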